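This account rests on a few compounds, and the source may have more. Where it says the series, first, only, none or still open, it means among the compounds named here.

The study sets four compounds that share a core against a functional assay on HCT-116 cells (Homo sapiens) for cytotoxicity, read by sulforhodamine B assay, with a stated time of 48 h, in the presence of a further agent that is not named here; on this read-out higher numbers stand for weaker inhibition and lower numbers for stronger inhibition. Compound 1, `O=C(CCCSSCCOCCOCCOc1cc(O)c(C(=O)CCc2ccc(O)cc2)c(O[C@@H]2O[C@H](CO)[C@@H](O)[C@H](O)[C@H]2O)c1)OCn1cc(F)c(=O)[nH]c1=O`, gives 23800 nM in this assay. Compound 2, `O=C(CCCSSCCOCCOCCOc1cc(O)c(C(=O)CCc2ccc(O)cc2)c(O)c1)OCn1cc(F)c(=O)[nH]c1=O`, is obtained from compound 1 by hydrogen in place of 3,4,5-trihydroxy-6-(hydroxymethyl)oxan-2-yl on an oxygen on an aromatic ring, and compound 2 gives 10500 nM in this assay. That change produced a 2.3-fold lower number from compound 1 to compound 2 (0.36 log units; beyond the scatter).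

Compound 3, `O=C(CCc1ccc(O)cc1)c1c(O)cc(OCCOCCOCCS)cc1O[C@@H]1O[C@H](CO)[C@@H](O)[C@H](O)[C@H]1O`, returns only a limit in this assay, > 100000 nM. Compound 3 therefore stands at the limit of > 100000 nM in this assay, at which 1 of the 3 values shown sits. How the core of compound 3 differs from the core of compound 1 is not broken down here.

Compound 4, `O=C(CCc1ccc(O)cc1)c1c(O)cc(OCCOCCOCCS)cc1O`, has not yet been measured in this assay. It is obtained from compound 3 by hydrogen in place of 3,4,5-trihydroxy-6-(hydroxymethyl)oxan-2-yl on an oxygen on an aromatic ring. The place of this change is described in the same words as for the change from compound 1 to compound 2, so it is the same change, made a second time.

Since compound 3 gives only a limit and the earlier change from compound 1 to compound 2 gave a 2.3-fold lower number from compound 1 to compound 2 (0.36 log units; beyond the scatter), the step from compound 3 to compound 4 in this assay is expected to be about a number no higher from compound 3 to compound 4 (the limit leaves the size open), though the starting point is not a number. Compound 4 is estimated to give roughly 100000 nM in this assay, with an expected range from 30000 nM to 300000 nM, and a real chance that this assay again reports only a limit for compound 4.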

Compound 4, half-maximal inhibitory concentration: 15900 nM
Compound 4: middle estimate off by 6.3-fold (0.80 log units), on the high side, and the stated range ends above it.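

In this assay, hydrogen in place of 3,4,5-trihydroxy-6-(hydroxymethyl)oxan-2-yl on an oxygen on an aromatic ring lowered the number on both cores, and on the second core the step is an at least 6.2-fold lower number from compound 3 to compound 4 (0.79 log units; beyond the scatter). The direction of the change therefore carried over from one core to the other in these two pairs, but its size did not: the same change on two cores in this assay, a 2.3-fold lower number (0.36 log units; beyond the scatter) from compound 1 to compound 2 and an at least 6.2-fold lower number (0.79 log units; beyond the scatter) from compound 3 to compound 4, at least 2.7-fold (0.44 log units) apart, beyond the scatter of two such steps Compound 3 gives > 100000 nM in this assay, which is a limit and not a number, so the second step has only a lower bound, and the two pairs do not show what sets the sizes of the steps apart.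

For the compounds shown here, with only two cores carrying this change, it remains open whether the same direction would hold on a third core. Also open, from the compounds shown here alone, is how a methyl group or an acetyl group on that same oxygen, in place of either 3,4,5-trihydroxy-6-(hydroxymethyl)oxan-2-yl or hydrogen, would read in this assay, and whether such a group would fall on the same side of the comparison.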